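A few compounds are considered here, and "the series" means these few. Any claim that something is new, unique, unknown or untested is made for them only; others in the source may bear on it.

Compound 1 `CC(C)(C)c1ccc(C(=O)N2CCC3(CC2)C(=O)N(CC(=O)N2CCCC(CO)C2)CN3c2ccccc2)cc1`: 8200 nM
Compound 2 `COC(=O)CCCNC(=O)CN1CN(c2ccccc2)C2(CCN(C(=O)c3ccc(C(C)(C)C)cc3)CC2)C1=O`: "not determined" (no result reported)
Compound 3 `CC(C)(C)c1ccc(C(=O)N2CCC3(CC2)C(=O)N(CC(=O)N2CCNCC2)CN3c2ccccc2)cc1`: 22000 nM

In an assay on HEK293 cells for displacement of a labelled ligand from NPC1-like intracellular cholesterol transporter 1 (Homo sapiens) (on this read-out lower numbers stand for stronger inhibition and higher numbers for weaker inhibition), compound 3 gives 22000 nM, the highest of the two numbers available, and its nearest neighbour is compound 1 with 8200 nM. For compound 2 this assay reports "not determined" (no result reported), so it offers no number to compare. Going by the values given here, the single step that connects the measured compounds, a 2.7-fold higher number from compound 1 to compound 3 (0.43 log units; beyond the scatter), exchanges 3-(hydroxymethyl)piperidin-1-yl for piperazin-1-yl on a carbonyl carbon.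

Compound 4 `CCOC(=O)C1CCCN(C(=O)CN2CN(c3ccccc3)C3(CCN(C(=O)c4ccc(C(C)(C)C)cc4)CC3)C2=O)C1` moves in the other direction from compound 3: 3-(ethoxycarbonyl)piperidin-1-yl in place of piperazin-1-yl on a carbonyl carbon. Among the compounds with values here, the one step known here, from compound 1 to compound 3, is the closest guide, since it also replaces a substituted piperidine with piperazine at the same carbonyl carbon, and it raised the number modestly. Reversing that kind of change is therefore expected to lower the number for compound 4 by a comparable, modest amount, a 2.4-fold lower number from compound 3 to compound 4 (0.39 log units; beyond the scatter), though the new ring carries an ester rather than a hydroxymethyl group, so the outcome may differ from compound 1. Compound 4 is estimated at 9000 nM in this assay, with a plausible range from 3000 nM to 27000 nM.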

Compound 4, half-maximal inhibitory concentration: 8200 nM
Compound 4: the middle estimate sits 1.1-fold (0.04 log units) above what was measured, within the range that was stated.
By their numbers in this assay, from the lowest: compounds 1 and 4 (each within the scatter of the next); then compound 3.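

In this assay, the step of a 2.7-fold lower number from compound 3 to compound 4 (0.43 log units; beyond the scatter) shows that the higher number of compound 3 is not tied to one particular partner: a second substituted piperidine, 3-(ethoxycarbonyl)piperidin-1-yl, also gives a lower number than piperazin-1-yl on this carbonyl carbon. Going by these compounds alone, the step of no change at the digits printed from compound 1 to compound 4 (within the scatter) adds something the earlier compounds could not show, namely that an ester and an alcohol on the saturated ring carbon cannot be told apart in this read-out, although ethoxycarbonyl and hydroxymethyl are quite different groups. No measurement at hand explains either result.

Still open, on these data alone, is whether the piperidine ring needs a substituent at all, which unsubstituted piperidin-1-yl would address, and whether a carboxylic acid in place of the ester would stay level with compound 4 at 8200 nM. Also open, as far as these compounds go, is whether the higher number of compound 3 goes with the free ring nitrogen of piperazin-1-yl, a question that 4-methylpiperazin-1-yl would help to answer.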